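Saturated Amine in Place of an Anilino Group

The compounds below may be only part of what the source reports. "The series", "measured", "known", "first", "only" and "open" are said of these compounds alone.

Three measured compounds share one core and differ only in the amine on an aromatic carbon. Compound 1 `Cc1ccc(Nc2nc(C(F)(F)F)ccc2CNC(=O)C(C)c2ccc(NS(C)(=O)=O)c(F)c2)cc1C` carries a (3,4-dimethylphenyl)amino group, and in a functional assay on CHO-K1 cells for antagonist activity at transient receptor potential cation channel subfamily V member 1 (Homo sapiens), read by FLIPR (on this read-out lower numbers stand for stronger inhibition and higher numbers for weaker inhibition), compound 1 gives 1160 nM. Compound 2 `CCCN(CCC)c1nc(C(F)(F)F)ccc1CNC(=O)C(C)c1ccc(NS(C)(=O)=O)c(F)c1`, with dipropylamino, gives 14.7 nM, and compound 3 `CC(C(=O)NCc1ccc(C(F)(F)F)nc1N(C)c1ccccc1)c1ccc(NS(C)(=O)=O)c(F)c1`, with methyl(phenyl)amino, gives 57.4 nM. Compound 3 thus holds the second highest of the three numbers: the step of a 20-fold lower number from compound 1 to compound 3 (1.31 log units; beyond the scatter) is large, whereas the step of a 3.9-fold higher number from compound 2 to compound 3 (0.59 log units; beyond the scatter) is modest. Compound 4 `CC(C(=O)NCc1ccc(C(F)(F)F)nc1N1CCC(C)(C)CC1)c1ccc(NS(C)(=O)=O)c(F)c1` takes the next step: 4,4-dimethylpiperidin-1-yl in place of methyl(phenyl)amino on an aromatic carbon. The step that bears on it most closely is the one from a saturated dialkylamino group to an aryl-bearing amine, which raised the number modestly; compound 4 reverses that kind of exchange. Because the step of a 3.9-fold higher number from compound 2 to compound 3 (0.59 log units; beyond the scatter) was modest, the expected step for compound 4 is also modest, downward, as a 2.3-fold lower number from compound 3 to compound 4 (0.36 log units; beyond the scatter). Compound 4 is therefore estimated at 25 nM, with a range from 8 nM to 80 nM.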

Compound 4, half-maximal inhibitory concentration: 8 nM
For compound 4 the middle estimate is 3.1-fold (0.49 log units) above the measured one, within the range that was stated.
By their numbers in this assay, from the lowest: compounds 4 and 2 (each within the scatter of the next); then compound 3; then compound 1.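

In this assay, putting 4,4-dimethylpiperidin-1-yl in place of methyl(phenyl)amino leaves the heavy-atom count unchanged and exchanges the aromatic carbon ring for a non-aromatic ring with 1 hetero atom, and the result is a 7.2-fold lower number from compound 3 to compound 4 (0.86 log units; beyond the scatter). The ring and the open chain cannot be told apart at this position: a 1.8-fold lower number from compound 2 to compound 4 (0.26 log units; within the scatter) lies within the scatter, whereas a 150-fold lower number from compound 1 to compound 4 (2.16 log units; beyond the scatter) is the widest step among these compounds. Nothing given here accounts for these steps.

The compounds shown leave open whether pyrrolidin-1-yl, morpholin-4-yl or piperidin-1-yl without the methyl groups would hold the number at this position. They also leave open how plain anilino would stand, which bears on how the gap between the two aryl-bearing amines divides between the nitrogen methyl and the ring methyls.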